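Tolerance of compound 3 in C8166 cells

A few compounds are considered here, and "the series" means these few. Any claim that something is new, unique, unknown or untested is made for them only; others in the source may bear on it.

In a functional assay on C8166 cells (Homo sapiens) for cytotoxicity, read by MTT assay, with a stated time of 72 h (a higher number here means that more compound is tolerated, a lower number that less compound is tolerated), compound 2 `Cc1ccc(S(=O)(=O)N2CC3(C[C@H]2C(=O)N/N=C/c2ccccc2Cl)SCCS3)cc1` gives > 404000 nM, which is a limit of the assay and not a number. Compound 1 `Cc1ccc(S(=O)(=O)N2CC3(C[C@H]2C(=O)N/N=C/c2ccccc2[N+](=O)[O-])SCCS3)cc1` gives 65000 nM. Among the measured compounds shown here, the one measured step, an at least 6.2-fold higher number from compound 1 to compound 2 (0.79 log units; beyond the scatter), is a change on the aromatic group, and it is the only guide here. Compound 3 `COc1cc(/C=N/NC(=O)[C@@H]2CC3(CN2S(=O)(=O)c2ccc(C)cc2)SCCS3)cc(OC)c1OC` carries 3,4,5-trimethoxyphenyl in place of 2-chlorophenyl on a carbon with a double bond to nitrogen. Given the reach of that measured step, a small move toward a lower number is expected, namely an at least 2.0-fold lower number from compound 2 to compound 3 (0.30 log units; that floor lies within the scatter). For compound 3 the estimated value is 200000 nM, with an expected range from 60000 nM to 400000 nM.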

Compound 3, half-maximal cytotoxic concentration: 327000 nM
For compound 3 the middle estimate is 1.6-fold (0.21 log units) below the measured one; measured number inside the range.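

With 3,4,5-trimethoxyphenyl on the carbon with a double bond to nitrogen, a second group now stands clear of 2-nitrophenyl in this assay: a 5.0-fold higher number from compound 1 to compound 3 (0.70 log units; beyond the scatter). Compound 1 is thus the one of the three set apart, and the size of the entering group does not bring the number down to its level. The other step, an at least 1.2-fold lower number from compound 2 to compound 3 (0.09 log units; that floor lies within the scatter), gives only a floor and fixes no order, as one end of it is a limit and not a number: the limit of > 404000 nM in this assay, at which 1 of the 3 values shown sits.

On these data alone, how far the tolerance of compound 2 extends stays open. So does whether a phenyl carrying an amine or a carboxylic acid would keep the number this high.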